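Pyrimidine series: carbonyl-linked furan in place of methoxyphenyl

The source may hold more compounds than are shown below. What is called first, only, known or untested is meant among the compounds shown, and "the series" means these compounds.

Measured so far in a functional assay on Jurkat cells for inhibition of nuclear factor NF-kappa-B complex (Homo sapiens); on this read-out lower numbers stand for stronger inhibition and higher numbers for weaker inhibition:
compound 1 `CCOC(=O)c1cnc(-c2ccncc2)nc1NN1C(=O)C=C(C)C1=O` gives 6000 nM
compound 2 `CCOC(=O)c1cnc(-c2csc(C)n2)nc1NN1C(=O)C=C(C)C1=O` gives 8000 nM
compound 3 `CCOC(=O)c1cnc(-c2ccc(OC)cc2)nc1NN1C(=O)C=C(C)C1=O` gives 900 nM

Compound 3 stands lowest of the three numbers; the two other values lie beyond the scatter from it. The two heteroaryl groups give values within the scatter of each other: a 1.3-fold higher number from compound 1 to compound 2 (0.12 log units; within the scatter).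

Compound 4 `CCOC(=O)c1cnc(C(=O)c2ccco2)nc1NN1C(=O)C=C(C)C1=O` is not yet measured. Its change from compound 3 is (furan-2-yl)carbonyl in place of 4-methoxyphenyl on an aromatic carbon.

The relevant steps are the two that end at compound 3, both swaps of an aromatic group on the same aromatic carbon: a 6.7-fold lower number from compound 1 to compound 3 (0.82 log units; beyond the scatter) and an 8.9-fold lower number from compound 2 to compound 3 (0.95 log units; beyond the scatter). Going by the values given here, no measured step puts a carbonyl-linked group at this carbon, so the change in compound 4 has no direct precedent. Among the compounds with values here, the only guide is that both alternatives to 4-methoxyphenyl so far gave clearly higher numbers, which argues for a step back upward. For compound 4 the expectation is therefore a 5.6-fold higher number from compound 3 to compound 4 (0.74 log units; beyond the scatter), with the estimate 5000 nM and a wide range from 1500 nM to 20000 nM.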

Compound 4, half-maximal inhibitory concentration: 700 nM
Beside the measured number, compound 4's estimate is 7.1-fold (0.85 log units) above it, outside the stated range (below it).
By their numbers in this assay, from the lowest: compounds 4 and 3 (each within the scatter of the next); then compounds 1 and 2 (each within the scatter of the next).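

In this assay, the carbon between two ring nitrogen atoms accepts a carbonyl-linked furan as well as a directly attached 4-methoxyphenyl: a 1.3-fold lower number from compound 3 to compound 4 (0.11 log units; within the scatter), so these two groups cannot be told apart here. Low numbers at this carbon are therefore not confined to 4-methoxyphenyl, and (furan-2-yl)carbonyl also separates clearly from both heteroaryl groups, with an 8.6-fold lower number from compound 1 to compound 4 (0.93 log units; beyond the scatter) and an 11-fold lower number from compound 2 to compound 4 (1.06 log units; beyond the scatter). No evidence is available on what lies behind this result.

Going by these compounds alone, with only one carbonyl-linked group, it remains open whether the carbonyl link or the furan ring matters more, and a benzoyl group or a morpholine at this carbon would help separate the two. Also open, going by these compounds, is how the series responds when the ethoxycarbonyl group, common to all four compounds, gives way to a carboxylic acid or an amide.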